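Trading naphthalen-1-yl for phenyl: what to expect

The source may hold more compounds than are shown below. What is called first, only, known or untested is meant among the compounds shown, and "the series" means these compounds.

Measured in an ADME assay on HEK-293T cells (Homo sapiens) for inhibition, read by CCK-8 assay, with a stated time of 48 h, tested at 20 uM; on this read-out lower numbers stand for less inhibition of growth and higher numbers for more inhibition of growth at the one concentration tested
compound 1 `N#C/C(=C\c1ccccc1OS(=O)(=O)c1ccc(Cl)cc1)C(=O)Nc1nnc(Cc2cccc3ccccc23)s1` gives 16%
compound 2 `N#C/C(=C\c1ccccc1OS(=O)(=O)c1ccc(F)cc1)C(=O)Nc1nnc(Cc2cccc3ccccc23)s1` gives 15%

For the measured compounds named here, only two numbers exist so far, and they cannot be told apart, so compound 1 stands level with its one measured neighbour. Going by the values given here, the single measured step is a number 1 percentage points lower from compound 1 to compound 2 (within the scatter), and it comes from fluoro in place of chloro on an aromatic carbon.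

Compound 3 `N#C/C(=C\c1ccccc1OS(=O)(=O)c1ccc(Cl)cc1)C(=O)Nc1nnc(Cc2ccccc2)s1` differs from compound 1 elsewhere: phenyl in place of naphthalen-1-yl on a saturated chain carbon bound to an aromatic carbon. In words, this is phenyl in place of naphthalen-1-yl on a saturated chain carbon bound to an aromatic carbon. Among the compounds with values here, no measured step covers this change, so the data give no direction for it, and the step from the halogen swap is only a loose guide to its size. A shift in this assay beyond the scatter is not expected. The expected step is a number 2 percentage points lower from compound 1 to compound 3 (within the scatter). For compound 3 the estimated value is 14%, within an expected range of 4% to 28%.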

Compound 3, percent growth inhibition at one concentration: 25%
Beside the measured number, compound 3's estimate is 11 percentage points below it, within the range that was stated.
By their numbers in this assay, from the lowest: compounds 2, 1 and 3 (each within the scatter of the next).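

In this assay, putting phenyl in place of naphthalen-1-yl on a saturated chain carbon bound to an aromatic carbon gives a number 9 percentage points higher from compound 1 to compound 3 (within the scatter), so this is no clear shift. For the compounds shown here, this is the first measured step at this position, which the halogen swap left untouched, and it shows that the group can go from 10 heavy atoms and 2 aromatic rings to 6 heavy atoms and one ring while the number stays within the usual scatter of repeat measurements. No measurement shown here gives a reason for this result.

Still open, on these data alone, is whether a different group on that chain carbon, such as an amine, a carboxylic acid or a longer carbon chain, would move the number beyond the scatter. Also open, as far as these compounds go, is whether fluoro in place of chloro would read the same alongside phenyl as it does alongside naphthalen-1-yl.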